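The compounds below may be only part of what the source reports. "The series", "measured", "known", "first", "only" and "open" are said of these compounds alone.

Compound 1 `CC(C)c1ccc(-c2cc(Cl)cc(C(=O)Nc3nn[nH]n3)n2)cc1`: 90%
Compound 2 `COc1cc(C(=O)Nc2nn[nH]n2)nc(-c2ccccc2)c1`: 100%

In a functional assay on the whole organism for inhibition, with Rattus norvegicus as the target, at a dose of 10 mg/kg by the oral route (on this read-out lower numbers stand for a weaker effect and higher numbers for a stronger effect at the one dose given), compound 1 gives 90%. Compound 2 gives 100% in this assay, the higher of the two numbers recorded, though compound 1 lies within the scatter of it, so the two cannot be told apart on this read-out. No pair of these compounds differs in only one place, so no single step within the measured set can be read off.

Compound 3 `COc1cc(C(=O)Nc2nn[nH]n2)nc(-c2cccc(Cl)c2)c1` has not yet been measured in this assay. It differs from compound 2 by one change: chloro in place of hydrogen on an aromatic carbon. For the measured compounds named here, nothing among the measured compounds shows what a chloro in that place does to the read-out, and compound 2 already sits at the top of the scale, which leaves no room for a rise. The step from compound 2 to compound 3 is therefore expected to be small and, if anything, downward, with no step beyond the scatter as the most likely outcome. The expected step is a number 8 percentage points lower from compound 2 to compound 3 (within the scatter). Compound 3 is estimated at 92% in this assay, within a range from 75% to 100%.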

Compound 3, a percentage reported as inhibition, in the whole organism at one dose (the size of the read-out at that dose, not a potency): 64%
For compound 3 the middle estimate is 28 percentage points above the measured one; the whole stated range lies above it.
By their numbers in this assay, from the lowest: compound 3; then compounds 1 and 2 (each within the scatter of the next).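

Replacing phenyl with 3-chlorophenyl gives a number 36 percentage points lower from compound 2 to compound 3 (beyond the scatter) in this assay at the one dose given, so this carbon of the six-membered aromatic ring, meta to a large group, does not tolerate every substituent without a change in the read-out. For the compounds shown here, a single added chlorine, one heavy atom with no ring and no hydrogen-bond donors or acceptors, is enough to produce a large step, something the earlier compounds could not show because no two of them differed in only one place. No available measurement explains this step.

The compounds shown leave open whether the loss is specific to chloro or would also follow from a fluoro, methyl or methoxy group at the same carbon. They also do not show whether a chloro on another carbon of the phenyl ring would give a step of similar size, or whether the same change would have a similar effect with another group in place of the methoxy group on the shared core.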